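This account rests on a few compounds, and the source may have more. Where it says the series, first, only, none or still open, it means among the compounds named here.

Compound 1, `CC(C)(C)c1ccc(Cn2cc(C(N)=O)c3c(N)ncnc32)cc1`, was tested in a functional assay on KB cells (Homo sapiens) for cytotoxicity (on this read-out lower numbers stand for stronger inhibition and higher numbers for weaker inhibition), where compound 1 gives 900 nM. Compound 2, `CC(C)(C)c1ccc(Cn2cc(C#N)c3c(N)ncnc32)cc1`, differs from it only by cyano in place of carbamoyl on an aromatic carbon; in this assay compound 2 gives 3000 nM, so a 3.3-fold higher number from compound 1 to compound 2 (0.52 log units; beyond the scatter). Compound 3, `COCCOCn1cc(C(N)=O)c2c(N)ncnc21`, carries another core; the difference between the two cores is not broken down here. In this assay compound 3 reaches only a limit of the assay, > 100000 nM, which is the limit of > 100000 nM in this assay, at which 1 of the 3 values shown sits. Compound 4, `COCCOCn1cc(C#N)c2c(N)ncnc21`, is not yet measured and stands to compound 3 through (cyano in place of carbamoyl on an aromatic carbon). The surroundings are not identical, since here the ring atom bears a (2-methoxyethoxy)methyl group (6 heavy atoms) rather than a large group, so this is the same kind of change. Resting on a 3.3-fold higher number from compound 1 to compound 2 (0.52 log units; beyond the scatter), the expected step in this assay is a step that the limit leaves unreadable from compound 3 to compound 4. Compound 4 is therefore estimated at 300000 nM, most likely again reported only as a limit.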

Compound 4, half-maximal inhibitory concentration: > 100000 nM
Compound 4 was reported as a limit; the forecaster's own chance of this, stated with the estimate: 90%; the middle value is on the limit's open side.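

Going by these compounds alone, compound 3 and compound 4 both stand at a limit in this assay, so no step between them can be read: the limit of > 100000 nM in this assay, at which 2 of the 4 values shown sit. As far as these compounds go, how far cyano in place of carbamoyl shifts the number on this smaller-substituted core stays open.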